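Replacing the Butyl Chain on a Weak Nitro Compound

The source may hold more compounds than are shown below. What is called first, only, known or untested is meant among the compounds shown, and "the series" means these compounds.

Compound 1 `CCCCC(=O)NC(=S)Nc1nc2cc([N+](=O)[O-])ccc2s1` is tested in a functional assay on MCF7 cells (Homo sapiens) for cytotoxicity, read by MTT assay, with a stated time of 24 h; on this read-out lower numbers stand for stronger inhibition and higher numbers for weaker inhibition. In this assay compound 1 gives > 100000 nM, which is a limit of the assay rather than a number (the limit of > 100000 nM in this assay, at which 1 of the 3 values shown sits). Compound 2 `CCCCC(=O)NC(=S)Nc1nc2cc(N)ccc2s1` gives 44700 nM and compound 3 `CCCCC(=O)NC(=S)Nc1nc2ccccc2s1` gives 36600 nM. The steps of an at least 2.2-fold lower number from compound 1 to compound 2 (0.34 log units; beyond the scatter) and an at least 2.7-fold lower number from compound 1 to compound 3 (0.43 log units; beyond the scatter) both alter the nitro group on the ring, while a 1.2-fold lower number from compound 2 to compound 3 (0.09 log units; within the scatter) stays within the scatter. Compound 4 `O=C(NC(=S)Nc1nc2cc([N+](=O)[O-])ccc2s1)c1cccs1` keeps the nitro and instead changes the acyl end: thiophen-2-yl in place of butyl on a carbonyl carbon. Going by the values given here, none of the measured steps touches this part of the molecule, so there is no basis for expecting movement beyond the scatter. The estimate for compound 4 is therefore 100000 nM (from 30000 nM to 300000 nM). That would mean an expected step of a number no higher from compound 1 to compound 4 (the limit leaves the size open).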

Compound 4, half-maximal inhibitory concentration: 35900 nM
The estimate for compound 4 lay 2.8-fold (0.44 log units) above the measured number; the range from low to high includes it.
By their numbers in this assay, from the lowest: compounds 4, 3 and 2 (each within the scatter of the next). At a limit, above all of these: compound 1.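

In this assay, thiophen-2-yl in place of butyl on a carbonyl carbon gives an at least 2.7-fold lower number from compound 1 to compound 4 (0.44 log units; beyond the scatter). Going by these compounds alone, until now, only changes to the nitro group had given steps beyond the scatter, so this is the first sign that the acyl end can also shift the read-out while the nitro stays in place. The full size of the step stays open, as compound 1 stands at a limit of the assay: the limit of > 100000 nM in this assay, at which 1 of the 4 values shown sits.

As far as these compounds go, whether a phenyl ring or a longer chain in this place would do the same remains open. So does whether thiophen-2-yl would act alike on the core of compound 3, which has no nitro.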